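The compounds below may be only part of what the source reports. "The series", "measured", "known", "first", "only" and "open" are said of these compounds alone.

Working notes on the series.

Three compounds have numbers in an ADME assay on Huh7.5.1 cells (Homo sapiens) for cytotoxicity, read by ATP content, with a stated time of 48 h; on this read-out higher numbers stand for lower toxicity in this test and lower numbers for higher toxicity in this test. Compound 1 `CC[C@@H]1C[C@H](CC)CN(CCCNC(=O)C2CCN(Cc3nc(-c4ccccc4C)oc3C)CC2)C1` gives 3470 nM in this assay. Compound 2 `Cc1ccccc1-c1nc(CN2CCC(C(=O)NCCCN3CC(C)(C)CC(C)(C)C3)CC2)c(C)o1` gives 4380 nM in this assay. Among the compounds with values here, the only single-point step so far is a 1.3-fold higher number from compound 1 to compound 2 (0.10 log units; within the scatter), and it sits at the far end of the chain, not on the aromatic end of the core. Within the data shown here, compound 3 `Cc1oc(-c2ccc(F)cc2)nc1CN1CCC(C(=O)NCCCN2C[C@H](C)C[C@H](C)C2)CC1` gives 12800 nM in this assay, the highest of the three numbers; its gaps to compound 2 and to compound 1 both lie beyond the scatter, but compound 3 differs from each of them in more than one place, so no single-point step on the aromatic end exists among the measured compounds.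

Compound 4 `COc1ccc(-c2nc(CN3CCC(C(=O)NCCCN4C[C@H](C)C[C@H](C)C4)CC3)c(C)o2)cc1OC` is the next one to be measured. It differs from compound 3 by 3,4-dimethoxyphenyl in place of 4-fluorophenyl on an aromatic carbon. Among the measured compounds shown here, no measured step bears on this position; the one step in hand, a 1.3-fold higher number from compound 1 to compound 2 (0.10 log units; within the scatter), was within the scatter and concerns a different part of the molecule. With nothing to anchor a direction, the expected step of a 1.1-fold lower number from compound 3 to compound 4 (0.03 log units; within the scatter) is none beyond the scatter, and a wide range is kept. For compound 4 the estimate in this assay is 12000 nM, expected between 4500 nM and 32000 nM.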

Compound 4, half-maximal cytotoxic concentration: 57200 nM
Estimate against measurement, compound 4: 4.8-fold (0.68 log units) below; the whole stated range lies below it.
By their numbers in this assay, from the lowest: compounds 1 and 2 (each within the scatter of the next); then compound 3; then compound 4.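

The aromatic end of the series now has its first single-point step. In this assay, within the data shown here, 3,4-dimethoxyphenyl in place of 4-fluorophenyl, on an aromatic carbon next to the ring nitrogen and next to the ring oxygen, gives a step beyond the scatter (a 4.5-fold higher number from compound 3 to compound 4 (0.65 log units; beyond the scatter)), so this position can move the read-out, in the direction of lower toxicity in this test, while the rest of the structure stays the same; the only earlier step (a 1.3-fold higher number from compound 1 to compound 2 (0.10 log units; within the scatter)) lay within the scatter and concerned the far end of the chain. Nothing in hand explains why this change moves the number.

The step replaces the fluorine and brings in both methoxy groups at once, so the compounds shown do not tell whether the loss of the fluorine, one methoxy group or the pair accounts for it, which a 4-methoxyphenyl or an unsubstituted phenyl at this place would help to separate. On these data alone, it also remains open whether the same change gives a step of similar size when the far end of the chain is that of compound 1 or compound 2.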